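This account rests on a few compounds, and the source may have more. Where it says the series, first, only, none or still open, it means among the compounds named here.

Compound 2 `CC(C)c1cccc(OC(=O)c2cn(-c3ccccc3)nc2-c2cccnc2)c1` is the only compound among those shown with an actual number in a functional assay on HL-60 cells (Homo sapiens) for cytotoxicity, read by MTT assay, with a stated time of 48 h; on this read-out higher numbers stand for weaker inhibition and lower numbers for stronger inhibition: in this assay compound 2 gives 23700 nM. Compound 1 `COc1ccc(OC(=O)c2cn(-c3ccccc3)nc2-c2cccnc2)cc1` returns only a limit of this assay, > 100000 nM. The step of an at least 4.2-fold lower number from compound 1 to compound 2 (0.62 log units; beyond the scatter) therefore rests on that limit (the limit of > 100000 nM in this assay, at which 1 of the 2 values shown sits). Compound 3 `CC(C)(C)c1ccc(OC(=O)c2cn(-c3ccccc3)nc2-c2cccnc2)cc1` differs from compound 2 by 4-(tert-butyl)phenyl in place of 3-isopropylphenyl on an oxygen next to a carbonyl group. Within the data shown here, the single measured step concerns another exchange on that same oxygen and gives no direct guide, so no change beyond the scatter is expected in either direction. Compound 3 is expected near compound 2, at a 1.1-fold higher number from compound 2 to compound 3 (0.02 log units; within the scatter). The estimate for compound 3 is 25000 nM, with a range from 8000 nM to 80000 nM.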

Compound 3, half-maximal inhibitory concentration: > 100000 nM
Compound 3: a limit, no number; the forecaster's own chance of this, stated with the estimate: 25%; middle value at least 4.0-fold (0.60 log units) from the limit.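

On this oxygen, 4-(tert-butyl)phenyl in place of 3-isopropylphenyl is not a neutral exchange in this assay: the data give an at least 4.2-fold higher number from compound 2 to compound 3 (0.62 log units; beyond the scatter). Both groups contain only carbon and carry no hydrogen-bond donors or acceptors, yet only compound 2 gives an actual number. Compound 3 gives only a limit, so the size of this step is a bound, and the step from compound 1 to compound 3 cannot be read: the limit of > 100000 nM in this assay, at which 2 of the 3 values shown sit.

As far as these compounds go, how a plain phenyl, or a phenyl carrying an amine or a carboxylic acid, would read on this oxygen stays open.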